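Alkanoyl for Aroyl on the Diacylhydrazine Core

The compounds below may be only part of what the source reports. "The series", "measured", "known", "first", "only" and "open" are said of these compounds alone.

The series shares a tert-butyl diacylhydrazine core. Compound 1 `CC(C)(C)N(NC(=O)c1ccccc1Br)C(=O)c1ccccc1Cl` carries 2-bromophenyl and 2-chlorophenyl on its two carbonyl carbons; in an assay on cells for agonist activity at ecdysone receptor (Bombyx mori), read by a luciferase reporter, with a stated time of 24 h (a lower number here means that less compound is needed, a higher number that more compound is needed for the effect), compound 1 gives 316 nM. Compound 2 `CCc1ccc(C(=O)NN(C(=O)c2ccccc2)C(C)(C)C)cc1` gives 4.9 nM, and compound 3 `CCc1ccc(C(=O)NN(C(=O)C2CC=CCC2)C(C)(C)C)cc1` gives 1000 nM. Compound 1 thus stands second highest of the three numbers, nearest to compound 3 and furthest from compound 2.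

Compound 4 `CCCCCCC(=O)NN(C(=O)c1ccccc1Cl)C(C)(C)C` differs from compound 1 in one place: hexyl in place of 2-bromophenyl on a carbonyl carbon.

For the measured compounds named here, the one measured step in this assay that bears on an aryl-to-aliphatic exchange on a carbonyl carbon is a 200-fold higher number from compound 2 to compound 3 (2.31 log units; beyond the scatter), where cyclohex-3-en-1-yl entered in place of phenyl. The change toward compound 4 goes further, to a chain with no ring at all, so a step in the same direction, toward a higher number, is expected, of a size at least comparable to that step. Since compound 1 already starts at 316 nM, the result may approach the upper working range of this assay.

For compound 4 the estimated value is 6000 nM, with a range from 800 nM to 50000 nM, meaning an expected step of a 19-fold higher number from compound 1 to compound 4 (1.28 log units; beyond the scatter).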

Compound 4, half-maximal effective concentration: 741 nM
Compound 4: the middle estimate sits 8.1-fold (0.91 log units) above what was measured, outside the stated range (below it).
By their numbers in this assay, from the lowest: compound 2; then compound 1; then compounds 4 and 3 (each within the scatter of the next).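

In this assay, removing the ring from this carbonyl carbon costs little: with hexyl entering in place of 2-bromophenyl, the result is a 2.3-fold higher number from compound 1 to compound 4 (0.37 log units; beyond the scatter). The earlier exchange of an aromatic ring for an aliphatic group, a 200-fold higher number from compound 2 to compound 3 (2.31 log units; beyond the scatter), lies on the other carbonyl carbon of the shared core, so the size of that step does not carry over to this position, at least with 2-chlorophenyl as the partner group. No measurement at hand accounts for the difference in size between the two steps.

Going by these compounds, how the number moves along the chain remains open, whether with a shorter butyl chain, a longer octyl chain, or a hexyl chain ending in a carboxylic acid. Also open, on these data alone, is whether the modest step at this position would hold with an unsubstituted phenyl in place of the 2-chlorophenyl on the other carbonyl carbon, since the two exchanges seen so far differ both in the position changed and in the groups around it.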